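The compounds below may be only part of what the source reports. "The series", "measured", "known", "first", "only" and "open" are said of these compounds alone.

So far, two compounds sharing one core have been tested in a functional assay on MCF7 cells (Homo sapiens) for cytotoxicity, read by sulforhodamine B assay; on this read-out higher numbers stand for lower toxicity in this test and lower numbers for higher toxicity in this test. Compound 1 `CC1=CC[C@@H]([C@@](C)(O)CCCC(C)(C)NC(=S)N/N=C\c2ccccc2)CC1` gives 60400 nM, and compound 2 `CC1=CC[C@@H]([C@@](C)(O)CCCC(C)(C)NC(=S)N/N=C\c2cccc([N+](=O)[O-])c2)CC1` gives 47300 nM. These two numbers lie within the usual scatter of repeated measurements, so this assay does not separate compound 2 from compound 1.

Compound 3 `CC1=CC[C@@H]([C@@](C)(O)CCCC(C)(C)NC(=S)N/N=C\c2ccc(Cl)cc2)CC1` keeps the shared core and changes one group: 4-chlorophenyl in place of 3-nitrophenyl on a carbon with a double bond to nitrogen. In words, this is 4-chlorophenyl in place of 3-nitrophenyl on a carbon with a double bond to nitrogen. Within the data shown here, no tested compound carries chlorine, so the data offer no direct measure of this change. Among the measured compounds shown here, the only measured step that bears on it is nitro in place of hydrogen on an aromatic carbon, which gave a 1.3-fold lower number from compound 1 to compound 2 (0.11 log units; within the scatter). On the strength of that single small step, no change beyond the scatter is expected in this assay, and no direction can be favoured. The estimated step is a 1.1-fold higher number from compound 2 to compound 3 (0.02 log units; within the scatter). Compound 3 is therefore expected at about 50000 nM, with an estimated range of 25000 nM to 100000 nM.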

Compound 3, concentration lethal to 50% of the cells: 44300 nM
Compound 3: the middle estimate sits 1.1-fold (0.05 log units) above what was measured; measured number inside the range.
By their numbers in this assay, from the lowest: compounds 3, 2 and 1 (each within the scatter of the next).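

In this assay the exchange at this position gives a 1.1-fold lower number from compound 2 to compound 3 (0.03 log units; within the scatter) and adding chlorine to the plain phenyl group of compound 1 gives a 1.4-fold lower number from compound 1 to compound 3 (0.13 log units; within the scatter), so neither step separates the compounds. Chlorine now joins nitro as a second kind of group on this aromatic ring, and phenyl, 3-nitrophenyl and 4-chlorophenyl on the carbon with a double bond to nitrogen all read alike in this test, which means the three compounds cannot be put in any order. No supporting measurement is available to explain why these groups read alike.

The two substituted compounds differ both in the group and in its place on the ring, so the shown data cannot tell whether either of these matters on its own, and a pair such as 3-chlorophenyl and 4-chlorophenyl would be needed to pull them apart. As far as these compounds go, it also remains open whether a quite different group on this ring, such as an amine or a carboxylic acid, would move the number beyond the scatter.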